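A few compounds are considered here, and "the series" means these few. Any claim that something is new, unique, unknown or untested is made for them only; others in the source may bear on it.

Compound 1 `CCOC(=O)c1ccc(-c2nn(Cc3ccccc3Cl)c3ccccc23)cc1` carries a 2-chlorobenzyl group on an aromatic nitrogen of the shared core. In a functional assay on cells (Platelet, Homo sapiens) for inhibition (on this read-out lower numbers stand for stronger inhibition and higher numbers for weaker inhibition), compound 1 gives > 10000 nM, which is a limit of the assay rather than a measured number. Compound 2 `CCOC(=O)c1ccc(-c2nn(Cc3ccncc3)c3ccccc23)cc1` has pyridin-4-yl in place of 2-chlorophenyl on a saturated chain carbon bound to an aromatic nitrogen. In this assay compound 2 gives > 10000 nM, again a limit. Compound 3 `CCOC(=O)c1ccc(-c2nn(-c3ccco3)c3ccccc23)cc1` has furan-2-yl in place of 2-chlorobenzyl on an aromatic nitrogen. In this assay compound 3 gives > 10000 nM, also a limit. Compound 1 thus stands at a limit only, and the two further values shown are limits as well. None of the steps can be read because the limit of > 10000 nM in this assay, at which 3 of the 3 values shown sit: the steps a step that the two limits leave unreadable from compound 1 to compound 2, a step that the two limits leave unreadable from compound 1 to compound 3 and a step that the two limits leave unreadable from compound 2 to compound 3 have no readable size or direction.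

Compound 4 `CCOC(=O)c1ccc(-c2nn(-c3ccoc3)c3ccccc23)cc1` is the next point. The change from compound 1 is furan-3-yl in place of 2-chlorobenzyl on an aromatic nitrogen. The nearest comparison is compound 3, whose value > 10000 nM is a limit. With no readable step to lean on, the step that the limit leaves unreadable from compound 1 to compound 4 is expected to be essentially flat, most likely ending at a limit once more. Compound 4 is therefore estimated to give 20000 nM, within a range from 5000 nM to 100000 nM.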

Compound 4, half-maximal inhibitory concentration: > 10000 nM
Compound 4: no number, only a limit; the forecaster's own chance of this, stated with the estimate: 85%; the middle value is on the limit's open side.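

Compound 4 gives > 10000 nM in this assay, which is again a limit and not a number. No step linking compound 4 with compound 1, compound 2 or compound 3 can be read, for one reason: the limit of > 10000 nM in this assay, at which 4 of the 4 values shown sit.

The compounds shown leave open whether any group on this aromatic nitrogen of the shared core can give a readable inhibition value.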